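This account rests on a few compounds, and the source may have more. Where it says the series, first, only, none or still open, it means among the compounds named here.

Measured compounds in a functional assay on Jurkat cells (Homo sapiens) for inhibition; on this read-out lower numbers stand for stronger inhibition and higher numbers for weaker inhibition: compound 1 `CCCCCCCCCCCCCCC(CN)NC(=O)OC(C)(C)C` gives 6000 nM; compound 2 `CCCCCCCCCCCCCCC(CNCC)NC(=O)OC(C)(C)C` gives 6000 nM; compound 3 `CCCCCCCCCCCCCCC(O)CNC1CCCCC1` gives 6000 nM.

Compound 3 stands level with compounds 1 and 2 in this assay, the three values lying within the scatter of each other. Compound 4 `CCCCCCCCCCCCCCC(O)CNCc1ccccc1` differs from compound 3 by benzyl in place of cyclohexyl on an amine nitrogen. Going by the values given here, the only measured step that bears on a substituent change at an amine nitrogen is no change at the digits printed from compound 1 to compound 2 (within the scatter), which stayed within the scatter. Among the compounds with values here, with no measured step exceeding the scatter, the expected change from compound 3 to compound 4 is no change at the digits printed from compound 3 to compound 4 (within the scatter), none beyond the scatter. Compound 4 is therefore estimated at 6000 nM in this assay, with a range from 3000 nM to 12000 nM.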

Compound 4, half-maximal inhibitory concentration: 27000 nM
Beside the measured number, compound 4's estimate is 4.5-fold (0.65 log units) below it; the whole stated range lies below it.
By their numbers in this assay, from the lowest: compounds 1, 2 and 3 (each within the scatter of the next); then compound 4.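

In this assay, going by these compounds alone, the change on this amine nitrogen gives the first step beyond the scatter: benzyl in place of cyclohexyl brings a 4.5-fold higher number from compound 3 to compound 4 (0.65 log units; beyond the scatter), which means weaker inhibition. The position therefore responds to the group it carries, which the ethyl step in the other pair had not shown. Nothing measured here explains the difference.

Benzyl differs from cyclohexyl both in its aromatic ring and in its extra carbon, and the compounds shown do not separate the two. A phenyl or a cyclohexylmethyl on the same nitrogen would bear on that question.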